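Fixing One Stereocentre on the Weakest Compound

The source may report more compounds than this note shows. Statements on the series, on what has been measured and on what is new or still open speak of the compounds shown alone.

In an assay on mitochondria for inhibition of Amine oxidase [flavin-containing] B (Bos taurus) (a higher number here means a weaker inhibitor, a lower number a stronger inhibitor), compound 1 `Cc1ccc(C2=NN(C(N)=S)C(c3ccc(Cl)cc3)C2)cc1` gives 15 nM, compound 2 `Cc1ccc(C2=NN(C(N)=S)[C@@H](c3ccc(Cl)cc3)C2)cc1` gives 2.7 nM, and compound 3 `NC(=S)N1N=C(c2ccc(F)cc2)CC1c1ccc(Cl)cc1` gives 1000 nM, the highest number of the three. Drawing the ring stereocentre as R gave a 5.6-fold lower number from compound 1 to compound 2 (0.74 log units; beyond the scatter), while fluoro in place of methyl gave a 67-fold higher number from compound 1 to compound 3 (1.82 log units; beyond the scatter). Compound 4 `NC(=S)N1N=C(c2ccc(F)cc2)C[C@@H]1c1ccc(Cl)cc1` alters compound 3 in the same way: the two compounds have the same atoms and bonds; at least one stereo element is drawn with a configuration in one of them and without one in the other: 1 of 1 stereo elements differ; a stereocentre at a saturated ring carbon is drawn without a configuration in compound 3 and R in compound 4. A drop is expected for compound 4 because the fact that one of compounds 1 and 2 is drawn with a defined configuration and the other without, at the place where they differ is also what separates compound 1 from compound 2, where the step was a 5.6-fold lower number from compound 1 to compound 2 (0.74 log units; beyond the scatter). A step of about that size, a 5.6-fold lower number from compound 3 to compound 4 (0.74 log units; beyond the scatter), is therefore expected here. Compound 4 is estimated at 180 nM, most likely between 60 nM and 600 nM.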

Compound 4, inhibition constant: 1400 nM
Compound 4: middle estimate off by 7.8-fold (0.89 log units), on the low side; measured number outside the range, above it.
By their numbers in this assay, from the lowest: compound 2; then compound 1; then compounds 3 and 4 (each within the scatter of the next).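

With fluoro on the aromatic carbon, drawing the stereocentre as R does not repeat the clear step seen with methyl: the result is a 1.4-fold higher number from compound 3 to compound 4 (0.15 log units; within the scatter). Comparing the two R compounds, fluoro in place of methyl gives a 520-fold higher number from compound 2 to compound 4 (2.71 log units; beyond the scatter), which is larger than the swap measured without a drawn configuration. The effect of this swap therefore depends on the core that carries it: the same change on two cores in this assay, a 67-fold higher number (1.82 log units; beyond the scatter) from compound 1 to compound 3 and a 520-fold higher number (2.71 log units; beyond the scatter) from compound 2 to compound 4, 7.8-fold (0.89 log units) apart, beyond the scatter of two such steps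

Going by these compounds, it remains open whether a methoxy or an ethyl group on that aromatic carbon would behave like methyl or like fluoro. On these data alone, the S form of either compound also remains open.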